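Methyl for methoxy at the limit of the assay

A few compounds are considered here, and "the series" means these few. Any claim that something is new, unique, unknown or untested is made for them only; others in the source may bear on it.

In a functional assay on PC-3 cells (Homo sapiens) for cytotoxicity, read by MTT assay, with a stated time of 72 h (on this read-out higher numbers stand for weaker inhibition and lower numbers for stronger inhibition), compound 1 `c1ccc2[nH]c(-n3cccn3)cc2c1` gives > 100000 nM as a limit of the assay, not a number. Compound 2 `COc1ccc2[nH]c3c(c4c(c5ccnn53)C(=O)NC4=O)c2c1` gives > 100000 nM as a limit too. It therefore stands where the whole series stands so far (the limit of > 100000 nM in this assay, at which 2 of the 2 values shown sit), with no numerical reading in this assay to place it against anything else.

Compound 3 `Cc1ccc2[nH]c3c(c4c(c5ccnn53)C(=O)NC4=O)c2c1` keeps the core of compound 2 and carries methyl in place of methoxy on an aromatic carbon. The site lies on a six-membered aromatic ring of carbon only, part of a fused or bridged system of five rings. Among the compounds with values here, the series holds no measured step that gives a size or direction for this change. The expected outcome is no shift beyond the usual scatter (a number no higher from compound 2 to compound 3 (the limit leaves the size open)), and another reading at the limit is considered the likeliest result. For compound 3 the estimated value is 100000 nM with an expected range from 30000 nM to 200000 nM in this assay for now.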

Compound 3, half-maximal inhibitory concentration: 75000 nM
Compound 3: the middle estimate sits 1.3-fold (0.12 log units) above what was measured; the range from low to high includes it.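

In this assay, within the data shown here, compound 3 gives 75000 nM, the first reading that is a number and not a limit, which shows that the shared core with methyl on this aromatic carbon can give a reading inside the measurable range. Compound 2 gives > 100000 nM, which is a limit of the assay. The step for methyl in place of methoxy is therefore only a floor, an at least 1.3-fold lower number from compound 2 to compound 3 (0.12 log units; that floor lies within the scatter), so this pair fixes neither the true size of the change nor any real gain, and most of the series still stands at the ceiling: the limit of > 100000 nM in this assay, at which 2 of the 3 values shown sit.

With only methoxy and methyl shown on this carbon, no trend across substituents can be drawn, and it remains open how an unsubstituted hydrogen, a chlorine atom or an amine would read there. From the compounds shown here alone, it also remains open whether any change on the shared core can move the number beyond the usual scatter of this assay.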